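A Methoxyphenyl Amide Where Dimethylphenyl Gave Only a Limit

The compounds below may be only part of what the source reports. "The series", "measured", "known", "first", "only" and "open" are said of these compounds alone.

Compound 2 `Cc1cccc(C)c1NC(=O)CSc1nnc(-c2ccoc2C)n1Cc1ccco1` stands at a limit of a functional assay on CHO cells for antagonist activity at Orexin/Hypocretin receptor type 1 (Homo sapiens), read by FLIPR and calcium flux; on this read-out lower numbers stand for stronger inhibition and higher numbers for weaker inhibition: in this assay compound 2 gives > 15800 nM, a limit rather than a number. Compound 1 `Cc1ccc(C)c(NC(=O)CSc2nnc(-c3ccoc3C)n2Cc2ccco2)c1` likewise reaches only a limit, > 15800 nM, so that a step that the two limits leave unreadable from compound 1 to compound 2. Compound 3 `COc1ccc(C)cc1NC(=O)CSc1nnc(-c2ccoc2C)n1Cc1ccco1` gives a measured 2510 nM, hence an at least 6.2-fold lower number from compound 2 to compound 3 (0.79 log units; beyond the scatter) and an at least 6.2-fold lower number from compound 1 to compound 3 (0.79 log units; beyond the scatter). Compound 4 `COc1ccc(NC(=O)CSc2nnc(-c3ccoc3C)n2Cc2ccco2)cc1` arises from compound 2 by 4-methoxyphenyl in place of 2,6-dimethylphenyl on an amide-type nitrogen. A lower number is expected, of modest size, because an at least 6.2-fold lower number from compound 2 to compound 3 (0.79 log units; beyond the scatter) also brought a methoxy group onto the amide-type nitrogen's ring. The estimate for compound 4 in this assay is 5000 nM, spanning 1500 nM to 16000 nM. That estimate means an expected at least 3.1-fold lower number from compound 2 to compound 4 (0.49 log units; beyond the scatter).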

Compound 4, inhibition constant: > 15800 nM
Compound 4 ended at the assay's limit; the forecaster's own chance of this, stated with the estimate: 35%; middle value at least 3.1-fold (0.49 log units) from the limit.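

In this assay, 4-methoxyphenyl in place of 2-methoxy-5-methylphenyl on the amide-type nitrogen gives an at least 6.2-fold higher number from compound 3 to compound 4 (0.79 log units; beyond the scatter), so a methoxy group on this ring does not by itself bring a measurable value; the ring's pattern of groups matters. Compound 4 reaches only a limit, and its steps from compound 1 and compound 2 cannot be read: the limit of > 15800 nM in this assay, at which 3 of the 4 values shown sit.

On these data alone, what stays open is how much the methoxy and the methyl of compound 3 each contribute. Also open, as far as these compounds go, is whether an ethoxy group or a chlorine in place of that methoxy would keep a measurable value.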